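Opening the Ring: From Compound 2 to Compound 3

A few compounds are considered here, and "the series" means these few. Any claim that something is new, unique, unknown or untested is made for them only; others in the source may bear on it.

Of the compounds shown here, two have been tested so far in a functional assay on MCF7 cells (Homo sapiens) for antiproliferative activity; on this read-out higher numbers stand for weaker inhibition and lower numbers for stronger inhibition. Compound 1, `CC(=O)Oc1ccc(C(=O)Nc2cc3ccc(OCC4CCN(C)C4)c(C)c3oc2=O)cc1CC=C(C)C`, gives 1880 nM in this assay. Compound 2, `CC(C)=CCc1cc(C(=O)Nc2cc3ccc(OCCCN4CCCC4)c(C)c3oc2=O)ccc1O`, gives 990 nM. Compound 2 has the lowest of the two numbers, but its nearest neighbour, compound 1, lies within the scatter of it, so the two cannot be put in order. Within the data shown here, they also differ in more than one place, so no single step between them is known.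

Compound 3, `CC(C)=CCc1cc(C(=O)Nc2cc3ccc(OCCCNC(C)C)c(C)c3oc2=O)ccc1O`, has not yet been measured. It differs from compound 2 in one place: isopropylamino in place of pyrrolidin-1-yl on a saturated chain carbon, three bonds along the chain from an oxygen on an aromatic ring. The group that leaves forms a five-membered non-aromatic ring; the group that enters has no ring and brings 1 hydrogen-bond donor. Among the measured compounds shown here, no measured pair shows what such a change does here, so there is nothing to build a direction on. The expected step from compound 2 to compound 3 is a 1.2-fold higher number from compound 2 to compound 3 (0.08 log units; within the scatter), that is, none beyond the scatter. For compound 3 the estimate in this assay is 1200 nM, with a range from 400 nM to 3600 nM.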

Compound 3, half-maximal inhibitory concentration: 740 nM
Compound 3: middle estimate off by 1.6-fold (0.21 log units), on the high side; measured number inside the range.
By their numbers in this assay, from the lowest: compounds 3, 2 and 1 (each within the scatter of the next, the first and the last beyond it).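

In this assay, isopropylamino in place of pyrrolidin-1-yl, on a saturated chain carbon three bonds along the chain from an oxygen on an aromatic ring, gives a 1.3-fold lower number from compound 2 to compound 3 (0.13 log units; within the scatter). Among these compounds, this is the first change in a single place, and it shows that, for this one pair, opening the five-membered ring and adding a hydrogen-bond donor leaves the number within the scatter. The position therefore tolerates this swap, although a single pair cannot show how far that tolerance extends, and nothing available explains why the two groups read alike.

The two amines alone do not show whether the hydrogen-bond donor or the ring matters at this position, so a tertiary open-chain amine such as dimethylamino, a secondary ring amine such as piperidin-4-yl, or a six-membered morpholin-4-yl in the same place would each test a different part of the question. On these data alone, it also remains open whether a group with no nitrogen, such as a hydroxyl or a carboxylic acid, or a longer chain carrying the same isopropylamino, would keep the number within the scatter.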